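The source may hold more compounds than are shown below. What is called first, only, known or untested is meant among the compounds shown, and "the series" means these compounds.

Measured so far, in a functional assay on CHO cells for agonist activity at Free fatty acid receptor 2 (Homo sapiens), read by cAMP accumulation; a higher number here means a weaker inhibitor, a lower number a stronger inhibitor:
compound 1 `Cc1csc(NC(=O)[C@H](c2ccc(Cl)cc2)C(C)C)n1` gives 1400 nM
compound 2 `CC(C)[C@H](C(=O)Nc1nc(C(F)(F)F)cs1)c1ccc(Cl)cc1` gives 17000 nM

Compound 2 stands with the higher of the two numbers, the weaker of the pair. Among the measured compounds shown here, the only measured step is a 12-fold higher number from compound 1 to compound 2 (1.08 log units; beyond the scatter). Compound 3 `CC(C)[C@H](C(=O)Nc1nc(C(C)(C)C)cs1)c1ccc(Cl)cc1` differs from compound 2 by tert-butyl in place of trifluoromethyl on an aromatic carbon. For the measured compounds named here, no measured step swaps these two groups, so the direction is uncertain, though a 12-fold higher number from compound 1 to compound 2 (1.08 log units; beyond the scatter) shows that exchanging the group at this carbon can move this assay strongly. Compound 3 is therefore expected to land between the two measured numbers, an estimated step of a 3.4-fold lower number from compound 2 to compound 3 (0.53 log units; beyond the scatter), giving 5000 nM with a range from 1500 nM to 25000 nM.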

Compound 3, half-maximal inhibitory concentration: 7900 nM
Beside the measured number, compound 3's estimate is 1.6-fold (0.20 log units) below it; the measured number falls inside the stated range.
By their numbers in this assay, from the lowest: compound 1; then compound 3; then compound 2.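

With a third group at this aromatic carbon, this assay gives tert-butyl a middle place: a 2.2-fold lower number from compound 2 to compound 3 (0.33 log units; beyond the scatter) recovers part of what trifluoromethyl lost, while a 5.6-fold higher number from compound 1 to compound 3 (0.75 log units; beyond the scatter) shows that the methyl level is not regained. Tert-butyl and trifluoromethyl have the same count of heavy atoms yet still differ beyond the scatter, so equal counts do not give equal numbers here. Nothing measured accounts for this order of the three groups. Still open, on these data alone, is how a plain hydrogen, an ethyl group or a chlorine would read at this carbon. An amine or a carboxylic acid there is also unknown, as is whether any group could go below the methyl compound.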